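Chloro placement on a thioxothiazolidinone series in H292 cells

This account rests on a few compounds, and the source may have more. Where it says the series, first, only, none or still open, it means among the compounds named here.

Three chlorinated analogues of one shared core have been measured in a functional assay on NCI-H292 cells (Homo sapiens) for cytotoxicity, read by MTT assay, with a stated time of 72 h, tested at 1.25 ug/mL; a higher number here means more inhibition of growth at the concentration tested, a lower number less inhibition of growth. Compound 1 `O=C1NC(=S)/C(=C/c2cccc(Cl)c2)S1` gives 3.35% in this assay. Compound 2 `O=C1NC(=S)/C(=C/c2ccccc2Cl)S1`, built from the same atoms joined differently, gives 10.6% in this assay; the difference between the two cores is not broken down here. Compound 3 `O=C1NC(=S)/C(=C/c2ccc(Cl)c(Cl)c2)S1` gives 9.18% in this assay. Among the three numbers that of compound 2 is the highest, but its gap to compound 3 and to compound 1 is within the scatter, so no order among them can be claimed.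

For the measured compounds named here, the one counted step runs from compound 1 to compound 3 (chloro in place of hydrogen on an aromatic carbon), and in this assay it amounts to a number 5.8 percentage points higher from compound 1 to compound 3 (within the scatter).

Compound 4 `O=C1NC(=S)/C(=C/c2ccc(Cl)cc2Cl)S1` has not yet been measured. It differs from compound 2 in this way (chloro in place of hydrogen on an aromatic carbon). This is the same kind of change as the step from compound 1 to compound 3, though not the same: in the measured step the entering chloro sits ortho to a chloro group, whereas in compound 4 it sits meta to a chloro group.

Because the measured step of a number 5.8 percentage points higher from compound 1 to compound 3 (within the scatter) is within the scatter, the account expects the step from compound 2 to compound 4 in this assay to be small as well, namely a number 3.4 percentage points higher from compound 2 to compound 4 (within the scatter). On that basis compound 4 is estimated at 14% in this assay, with a range expected from 2% to 27%.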

Compound 4, percent growth inhibition at one concentration: 12.1%
Beside the measured number, compound 4's estimate is 1.9 percentage points above it; the range from low to high includes it.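

In this assay the new step is a number 1.5 percentage points higher from compound 2 to compound 4 (within the scatter), so on the core of compound 2, as on the core of compound 1, chloro in place of hydrogen on an aromatic carbon leaves the reading within the scatter. Set beside the earlier step, the change shows no difference between the two cores: the same change on two cores in this assay, a number 5.8 percentage points higher (within the scatter) from compound 1 to compound 3 and a number 1.5 percentage points higher (within the scatter) from compound 2 to compound 4, 4.3 percentage points apart, within the scatter of two such steps This supports carrying the change between these two cores only in the limited sense that neither step can be told from the scatter, and it does not show that the added chloro raises growth inhibition on either core, nor that a step of readable size would carry over, since none has been seen for this change.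

All four compounds shown carry only chloro on the aromatic ring and were read at a single concentration, where every number stays low, so nothing here says how the series behaves where growth inhibition is substantial. From the compounds shown here alone, whether a hydroxyl group, an amine or a carboxylic acid on that ring, or a longer chain in place of the amide hydrogen, would move the reading beyond the scatter remains open.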